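Replacing the Hydroxymethyl by a Piperazinylpropyl Ketone Chain

A few compounds are considered here, and "the series" means these few. Any claim that something is new, unique, unknown or untested is made for them only; others in the source may bear on it.

Measured compounds:
compound 1, `CN1CCN(CCCC(O)c2ccc(-c3ccc(N4C[C@H](Cn5ccnn5)OC4=O)cc3F)cn2)CC1`, 41000 nM
compound 2, `O=C1O[C@@H](Cn2ccnn2)CN1c1ccc(-c2ccc(CO)nc2)c(F)c1`, 4800 nM

In an assay for inhibition of Amine oxidase [flavin-containing] A (Homo sapiens) (on this read-out lower numbers stand for stronger inhibition and higher numbers for weaker inhibition), compound 2 gives the lowest of the two numbers shown; the only measured step is an 8.5-fold lower number from compound 1 to compound 2 (0.93 log units; beyond the scatter). Compound 3, `CN1CCN(CCCC(=O)c2ccc(-c3ccc(N4C[C@H](Cn5ccnn5)OC4=O)cc3F)cn2)CC1`, differs from compound 2 by (3-(4-methylpiperazin-1-yl)propyl)carbonyl in place of hydroxymethyl on an aromatic carbon. On these data alone, the step of an 8.5-fold lower number from compound 1 to compound 2 (0.93 log units; beyond the scatter) bears on this change: read in reverse, installing the same chain on compound 2 went with a higher number, though there the carbon carried a hydroxyl rather than a carbonyl, which remains untested. A rise of about a 5.2-fold higher number from compound 2 to compound 3 (0.72 log units; beyond the scatter) is therefore expected for compound 3. Compound 3 is estimated at 25000 nM in this assay, with a range of 6000 nM to 90000 nM.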

Compound 3, inhibition constant: 10500 nM
Beside the measured number, compound 3's estimate is 2.4-fold (0.38 log units) above it; low and high end bracket the measured number.
By their numbers in this assay, from the lowest: compound 2; then compound 3; then compound 1.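

At this aromatic carbon next to the ring nitrogen, the (3-(4-methylpiperazin-1-yl)propyl)carbonyl chain still goes with weaker inhibition than hydroxymethyl in this assay, with a 2.2-fold higher number from compound 2 to compound 3 (0.34 log units; beyond the scatter). The form of the chain carbon attached to the ring also matters, which the earlier pair could not show: a carbonyl there in place of the hydroxyl-bearing carbon gives a 3.9-fold lower number from compound 1 to compound 3 (0.59 log units; beyond the scatter). Nothing available explains either step. On these data alone, it remains open whether a shorter chain, or a morpholine in place of the 4-methylpiperazine, would bring the number below that of compound 2.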